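The source may report more compounds than this note shows. Statements on the series, on what has been measured and on what is new or still open speak of the compounds shown alone.

Compound 2, `CCCC1(Cc2ccccc2)OS(=O)(=O)C=C1OCc1ccccc1`, was tested in an ADME assay on HEL cells (Homo sapiens) for cytotoxicity, with a stated time of 3 days; a lower number here means that less compound is tolerated, a higher number that more compound is tolerated. In this assay compound 2 gives >= 400000 nM, which is a limit of the measurement rather than a number. Compound 1, `CCC1(Cc2ccccc2)OS(=O)(=O)C=C1OCc1ccc(Cl)c(Cl)c1`, was tested in the same way. In this assay compound 1 gives >= 20000 nM, again a limit rather than a number. Among the measured compounds shown here, compound 2 thus stands at a limit, and the one further value shown beside it is also a limit, so the two compounds cannot be placed in order against each other.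

Compound 3, `CCC1(Cc2ccccc2)OS(=O)(=O)C=C1OCc1ccccc1`, has not yet been measured in this assay. It differs from compound 2 in a single spot: hydrogen in place of methyl on a saturated chain carbon, two bonds along the chain from a saturated ring carbon. Seen from one bond further out, the chain is shortened from propyl to ethyl. For the measured compounds named here, no measured pair in this set shows what such a shortening does here. A change of this size is expected to stay within the usual scatter of this assay. The step of a number no higher from compound 2 to compound 3 (the limit leaves the size open) is expected to amount to no real change. Compound 3 is therefore estimated to give 400000 nM, within a range from 100000 nM to 1000000 nM.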

Compound 3, minimum cytotoxic concentration: >= 50000 nM
Compound 3 ended at the assay's limit; the forecaster's own chance of this, stated with the estimate: 85%; the middle value is on the limit's open side.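

In this assay, compound 3 also stands at a limit rather than a number, as do compound 1 and compound 2, so the steps from compound 2 and compound 1 to compound 3 cannot be read. The compounds shown leave open whether shortening propyl to ethyl, or replacing 3,4-dichlorophenyl with phenyl, changes the tolerated concentration at all.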